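A few compounds are considered here, and "the series" means these few. Any claim that something is new, unique, unknown or untested is made for them only; others in the source may bear on it.

Measured so far in a functional assay on MCF7 cells (Homo sapiens), tested at 5 uM; a lower number here means a stronger effect, a higher number a weaker effect of the compound at the concentration tested: compound 1 `C=CCOc1c(C)c(C)c2c(c1C)CCC(C)(COc1ccc(/C=C3\SC(=O)NC3=O)cc1OC)O2` gives 5%; compound 2 `CCOc1cc(/C=C2\SC(=O)NC2=O)ccc1OCC1(C)CCc2c(C)c(OCC=C(C)C)c(C)c(C)c2O1` gives 84%; compound 3 `COc1cc(/C=C2\SC(=O)NC2=O)ccc1OCC1(C)CCc2c(C)c(OCC=C(C)C)c(C)c(C)c2O1` gives 78%.

Compound 1 stands lowest of these three numbers. Its nearest neighbour is compound 3, as a number 73 percentage points higher from compound 1 to compound 3 (beyond the scatter) shows; compound 2 lies further off, its value being still higher. Compound 4 `C=CCOc1c(C)c(C)c2c(c1C)CCC(C)(COc1ccc(/C=C3\SC(=O)NC3=O)cc1Br)O2` is the next compound, and it differs from compound 1 in one place: bromo in place of methoxy on an aromatic carbon. For the measured compounds named here, no measured step covers this exchange. The step of a number 73 percentage points higher from compound 1 to compound 3 (beyond the scatter) concerns a chain on the other ring, and the step of a number 6 percentage points lower from compound 2 to compound 3 (within the scatter), which alters a group on the same aromatic carbon, lay within the scatter. Without a guiding step, compound 4 is expected to move only modestly, a number 10 percentage points higher from compound 1 to compound 4 (within the scatter). Compound 4 is therefore estimated at 15%, within a range from 0% to 45%.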

Compound 4, a percentage reported as activity, at one concentration (the size of the read-out at that concentration, not a potency): 98%
Compound 4: middle estimate off by 83 percentage points, on the low side; the whole stated range lies below it.
By their numbers in this assay, from the lowest: compound 1; then compounds 3 and 2 (each within the scatter of the next); then compound 4.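

In this assay, bromo in place of methoxy on this aromatic carbon gives a number 93 percentage points higher from compound 1 to compound 4 (beyond the scatter), so a change at this position alone can carry a large step. For the compounds shown here, the only earlier change on this carbon, a number 6 percentage points lower from compound 2 to compound 3 (within the scatter), showed no such sensitivity, though both of those compounds already had high numbers. Nothing at hand explains why this exchange has so large an effect.

The compounds shown leave open whether ethoxy on this carbon would keep the low number of compound 1. They also leave open how a hydroxyl, a chloro or an amine would behave here.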